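From 3-chlorophenyl to 3,4-dimethylphenyl on compound 2

The source may hold more compounds than are shown below. What is called first, only, known or untested is meant among the compounds shown, and "the series" means these compounds.

Compound 1 `Fc1ccc(C(CCCCOCc2ccc(Oc3ccc(Cl)cc3)cc2)c2ccc(F)cc2)cc1`: > 20000 nM (a limit)
Compound 2 `O=C(NCCCCC(c1ccc(F)cc1)c1ccc(F)cc1)Nc1cccc(Cl)c1`: 5070 nM

Among the compounds with values here, in a functional assay on MDA-MB-231 cells (Homo sapiens) for cytotoxicity, read by MTT assay, with a stated time of 48 h (a higher number here means a weaker inhibitor, a lower number a stronger inhibitor), compound 2 gives 5070 nM, the only actual number so far. Compound 1 is reported only as a limit, > 20000 nM.

Compound 3 `Cc1ccc(NC(=O)NCCCCC(c2ccc(F)cc2)c2ccc(F)cc2)cc1C` has not yet been measured. It departs from compound 2 at a single place: 3,4-dimethylphenyl in place of 3-chlorophenyl on an amide-type nitrogen. That puts 3,4-dimethylphenyl in place of 3-chlorophenyl on an amide-type nitrogen. Within the data shown here, no measured pair yet shows what such a change does in this assay, so no step beyond the scatter is expected, in either direction. The expected change is a 1.2-fold higher number from compound 2 to compound 3 (0.07 log units; within the scatter). Compound 3 is estimated at 6000 nM, with an expected range of 2500 nM to 15000 nM.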

Compound 3, half-maximal inhibitory concentration: > 20000 nM
Compound 3: a limit, no number; the forecaster's own chance of this, stated with the estimate: 12%; middle value at least 3.3-fold (0.52 log units) from the limit.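

In this assay, within the data shown here, the change from 3-chlorophenyl to 3,4-dimethylphenyl on the amide-type nitrogen gives an at least 3.9-fold higher number from compound 2 to compound 3 (0.59 log units; beyond the scatter) and is the first measured step here, showing that this position responds to the group it carries. Compound 3 has only a limit, > 20000 nM and no number, so the step sets a floor and not a size: the limit of > 20000 nM in this assay, at which 2 of the 3 values shown sit 

The compounds shown leave open whether losing the chlorine or gaining the two methyl groups decides this outcome. They also leave open how a plain phenyl, or a phenyl carrying an amine or a carboxylic acid, would read in this place.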